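Weak growth inhibitors: dimethylamino to phenyl

A few compounds are considered here, and "the series" means these few. Any claim that something is new, unique, unknown or untested is made for them only; others in the source may bear on it.

Measured in a functional assay on DU-145 cells (Homo sapiens) for inhibition, read by trypan blue exclusion, with a stated time of 96 h (a higher number here means a weaker inhibitor of growth, a lower number a stronger inhibitor of growth), so far:
- Compound 1 `Cc1ccc(S/C(=C/c2ccc(N(C)C)cc2)C(=O)c2ccc(Cl)cc2)cc1` gives > 100000 nM.
- Compound 2 `CN(C)c1ccc(/C=C(/SCc2ccc(Cl)cc2Cl)C(=O)c2ccc(Cl)cc2)cc1` gives 50000 nM.

Compound 1 gives > 100000 nM, which is a limit of the assay and not a number. Its place in the series is therefore known only as a limit, and the evidence on that reads (the limit of > 100000 nM in this assay, at which 1 of the 2 values shown sits).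

Compound 3 `Cc1ccc(S/C(=C/c2ccc(-c3ccccc3)cc2)C(=O)c2ccc(Cl)cc2)cc1` carries phenyl in place of dimethylamino on an aromatic carbon, para to a large group (phenyl in place of dimethylamino on an aromatic carbon).

One measured step exists, an at least 2.0-fold lower number from compound 1 to compound 2 (0.30 log units; that floor lies within the scatter). It concerns the group on sulfur, not the place changed here, and its floor lies within the scatter. Among the compounds with values here, no measured step replaces dimethylamino, so the data give no basis for a step beyond the scatter in this assay in either direction. The expected outcome stays in the weak region, near compound 2 at 50000 nM. Compound 3 may also be expected to end at the same assay limit as compound 1.

The expected step is a number no higher from compound 1 to compound 3 (the limit leaves the size open).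

The estimated value for compound 3 is 100000 nM, with an expected range of 30000 nM to 300000 nM.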

Compound 3, concentration for 50% growth inhibition: 50000 nM
For compound 3 the middle estimate is 2.0-fold (0.30 log units) above the measured one, and the stated range covers the measured number.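

In this assay, the place on the aromatic carbon that held dimethylamino now has a measured replacement, and the step reads an at least 2.0-fold lower number from compound 1 to compound 3 (0.30 log units; that floor lies within the scatter). Within the data shown here, this is the first measured change at this place, and with phenyl there compound 3 gives 50000 nM, so a group without nitrogen still yields a number within the range of the assay, though that number remains in the weak region. Compound 1 gives > 100000 nM, which is a limit of the assay and not a number, so the step has only a floor and its true size stays unknown: the limit of > 100000 nM in this assay, at which 1 of the 3 values shown sits.

Still open, as far as these compounds go, is whether any group at this place can move growth inhibition out of the weak region, for example a methoxy group, a morpholine ring or a carboxylic acid. Also open, from the compounds shown here alone, is whether the phenyl in place of dimethylamino would give a similar step when the sulfur carries 2,4-dichlorobenzyl, as in compound 2, rather than 4-methylphenyl.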